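Swapping a Cyclopentyl for a Methylsulfonyl Group

A few compounds are considered here, and "the series" means these few. Any claim that something is new, unique, unknown or untested is made for them only; others in the source may bear on it.

For the measured compounds named here, compound 3 `CC(C)(C)c1ccc(NC(=O)c2ccc(-c3ncccc3NC3CCCC3)cc2)cc1` gives 44 nM in a functional assay for antagonist activity at transient receptor potential cation channel subfamily V member 1 (Rattus norvegicus) (on this read-out higher numbers stand for weaker inhibition and lower numbers for stronger inhibition), the highest of the three numbers measured so far. Compound 2 `CCCNc1cccnc1-c1ccc(C(=O)Nc2ccc(C(C)(C)C)cc2)cc1` gives 37 nM, and the step of a 1.2-fold higher number from compound 2 to compound 3 (0.08 log units; within the scatter) shows these two lie within the usual scatter of each other. Compound 1 `CC(C)(C)c1ccc(NC(=O)c2ccc(-c3ncccc3F)cc2)cc1` gives 1 nM; the steps of a 37-fold higher number from compound 1 to compound 2 (1.57 log units; beyond the scatter) and a 44-fold higher number from compound 1 to compound 3 (1.64 log units; beyond the scatter) show that putting either amino group in place of fluoro raised the number strongly.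

Compound 4 `CC(C)(C)c1ccc(NC(=O)c2ccc(-c3ncccc3NS(C)(=O)=O)cc2)cc1` differs from compound 3 by methylsulfonyl in place of cyclopentyl on a nitrogen on an aromatic ring. Going by the values given here, the steps that bear on this change are a 1.2-fold higher number from compound 2 to compound 3 (0.08 log units; within the scatter), which concerns the same nitrogen and is small, and a 44-fold higher number from compound 1 to compound 3 (1.64 log units; beyond the scatter), which is large but concerns a different exchange. Among the compounds with values here, no measured step covers a methylsulfonyl on this nitrogen, so the uncertainty is wide. The expected step is a 1.4-fold higher number from compound 3 to compound 4 (0.13 log units; within the scatter), nothing beyond the scatter. Compound 4 is therefore estimated at 60 nM, with a range from 10 nM to 400 nM.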

Compound 4, half-maximal inhibitory concentration: 35 nM
For compound 4 the middle estimate is 1.7-fold (0.23 log units) above the measured one; low and high end bracket the measured number.
By their numbers in this assay, from the lowest: compound 1; then compounds 4, 2 and 3 (each within the scatter of the next).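

On the nitrogen on the aromatic ring, methylsulfonyl, which has no ring and has hydrogen-bond acceptors that cyclopentyl lacks, gives a number within the scatter of both alkyl groups in this assay (a 1.3-fold lower number from compound 3 to compound 4 (0.10 log units; within the scatter); a 1.1-fold lower number from compound 2 to compound 4 (0.02 log units; within the scatter)). Three quite different groups on this nitrogen thus read alike, and the methanesulfonamido group falls with the two amino groups, far from the fluoro of compound 1 (a 35-fold higher number from compound 1 to compound 4 (1.54 log units; beyond the scatter)). Nothing available explains either the match among these three groups or the gap to fluoro.

Still open, going by these compounds, is whether a plain amine, with only hydrogen on this nitrogen, or an acetyl group there would read like these three compounds or closer to compound 1. Also open, on these data alone, is how a chloro or methoxy group in place of fluoro would read.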